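This account rests on a few compounds, and the source may have more. Where it says the series, first, only, none or still open, it means among the compounds named here.

Compound 3 `CC(C)n1ncc2c(C(=O)Nc3ccccc3F)cc(-c3cccs3)nc21` has the highest of the two numbers seen in an ADME assay on LLC-MK2 cells (Macaca mulatta) for cytotoxicity, read by spectrophotometry and crystal violet staining, with a stated time of 4 days (on this read-out higher numbers stand for lower toxicity in this test and lower numbers for higher toxicity in this test), giving 50000 nM. Its nearest neighbour, compound 2 `CC(C)n1ncc2c(C(=O)Nc3cc(C(N)=O)ccc3F)cc(-c3cccs3)nc21`, gives 25000 nM, which lies within the scatter of that number. Compound 1 `CC(C)n1ncc2c(C(=O)Nc3cccc(F)c3)cc(-c3cccs3)nc21` gives only a limit of the test, > 200000 nM. The measured steps, an at least 4.0-fold lower number from compound 1 to compound 3 (0.60 log units; beyond the scatter) and a 2.0-fold higher number from compound 2 to compound 3 (0.30 log units; within the scatter), both concern the ring on the amide nitrogen, not the ring changed here. Compound 4 `CC(C)n1ncc2c(C(=O)Nc3ccccc3F)cc(-c3ccccn3)nc21` differs from compound 3 in a single place: pyridin-2-yl in place of thiophen-2-yl on an aromatic carbon. Among the compounds with values here, no measured step bears on this change, so no step beyond the scatter is expected, no change at the digits printed from compound 3 to compound 4 (within the scatter). Compound 4 is therefore estimated at 50000 nM, within a range from 15000 nM to 200000 nM.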

Compound 4, half-maximal cytotoxic concentration: 100000 nM
Compound 4: the middle estimate sits 2.0-fold (0.30 log units) below what was measured, and the stated range covers the measured number.
By their numbers in this assay, from the lowest: compounds 2, 3 and 4 (each within the scatter of the next, the first and the last beyond it). At a limit, above all of these: compound 1.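

This is the first change shown on the aromatic carbon next to the ring nitrogen, and in this assay pyridin-2-yl in place of thiophen-2-yl gives a 2.0-fold higher number from compound 3 to compound 4 (0.30 log units; within the scatter). Within the data shown here, at this place, then, a six-membered aromatic ring stands in for a five-membered one without a shift beyond the scatter, whereas the earlier steps concerned only the ring on the amide nitrogen. Only compound 1 sits at a limit of the test: the limit of > 200000 nM in this assay, at which 1 of the 4 values shown sits.

Still open, on these data alone, is how a plain phenyl ring, an amine or a carboxylic acid on this carbon would read. Also open, as far as these compounds go, is whether the same swap gives a similar result with another ring on the amide nitrogen.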